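The source may hold more compounds than are shown below. What is called first, only, known or untested is meant among the compounds shown, and "the series" means these compounds.

Compound 1 `ClCc1cccc(Cn2cnc3ncnc(Cl)c32)c1`: in a functional assay on NCI/ADR-RES cells (Homo sapiens) for cytotoxicity, read by sulforhodamine B assay, with a stated time of 48 h (on this read-out lower numbers stand for stronger inhibition of growth and higher numbers for weaker inhibition of growth), compound 1 gives 9770 nM. Compound 2 `ClCc1cccc(Cn2cnc3c(Cl)nc(Cl)nc32)c1`: in this assay compound 2 gives 5240 nM.

Compound 1 stands highest of the two numbers, with compound 2 nearest; the gap between them lies within the scatter, so the two show no real difference. Compound 3 `ClCc1cccc(Cn2cnc3nc(Cl)nc(Cl)c32)c1` differs from compound 1 by chloro in place of hydrogen on an aromatic carbon. Within the data shown here, no step between measured compounds is known, and compound 2, which also carries two chloro groups on the shared core, sits within the scatter of compound 1. The step from compound 1 to compound 3 is therefore expected to be small, a 1.8-fold lower number from compound 1 to compound 3 (0.25 log units; within the scatter), toward a lower number if anything. Compound 3 is estimated at 5500 nM, in a range from 2000 nM to 15000 nM.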

Compound 3, concentration for total growth inhibition: 3090 nM
Estimate against measurement, compound 3: 1.8-fold (0.25 log units) above; the range from low to high includes it.
By their numbers in this assay, from the lowest: compounds 3, 2 and 1 (each within the scatter of the next, the first and the last beyond it).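

In this assay, among these compounds, placing a chloro group in place of hydrogen on the aromatic carbon between two ring nitrogen atoms gives a 3.2-fold lower number from compound 1 to compound 3 (0.50 log units; beyond the scatter), a modest step beyond the scatter and the only one here between compounds that differ in one place. It shows that this position accepts a chloro group and that growth inhibition grows stronger with it. No measurement shown here accounts for the change.

On these data alone, whether an amine, a methoxy group or a bromo group at this position would give a similar step remains open.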